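Urea and thiourea pairs across two cores

The compounds below may be only part of what the source reports. "The series", "measured", "known", "first", "only" and "open" are said of these compounds alone.

Compound 1 `CC1(C)CC(C)(C)c2cc(NC(=O)Nc3ccc([N+](=O)[O-])cc3)ccc2O1` and compound 2 `CC1(C)CC(C)(C)c2cc(NC(=O)Nc3ccc(C(F)(F)F)cc3)ccc2O1` share one core and are both measured in a functional assay on A2780 cells (Homo sapiens) for inhibition, with a stated time of 72 h, tested at 10 uM; on this read-out lower numbers stand for less inhibition of growth and higher numbers for more inhibition of growth at the one concentration tested. In this assay compound 2 gives 88.4%, and compound 1 gives 79%. The step of a number 9.4 percentage points lower from compound 2 to compound 1 (within the scatter) comes with the change (nitro in place of trifluoromethyl on an aromatic carbon). Compound 3 `CC1(C)CCOc2ccc(NC(=S)Nc3ccc(C(F)(F)F)cc3)cc21` carries a different core; how that core differs from the core of compound 2 is not broken down here. In this assay compound 3 gives 28%, the lowest of the three numbers and beyond the scatter from both compound 1 and compound 2. Compound 4 `CC1(C)CCOc2ccc(NC(=S)Nc3ccc([N+](=O)[O-])cc3)cc21` has not yet been measured. Going by the values given here, it arises from compound 3 by nitro in place of trifluoromethyl on an aromatic carbon, the same change as the one from compound 2 to compound 1, at a place described in the same words. The step of a number 4 percentage points lower from compound 3 to compound 4 (within the scatter) is expected to be small, because the same change earlier gave a number 9.4 percentage points lower from compound 2 to compound 1 (within the scatter), a step within the scatter. Compound 4 is therefore estimated at 24%, with the expected range running from 5% to 45%.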

Compound 4, percent growth inhibition at one concentration: 19%
The estimate for compound 4 lay 5 percentage points above the measured number, and the stated range covers the measured number.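

The trifluoromethyl-to-nitro change carries over between the two cores in this assay, with the new step, a number 9 percentage points lower from compound 3 to compound 4 (within the scatter), matching the earlier one: the same change on two cores in this assay, a number 9.4 percentage points lower (within the scatter) from compound 2 to compound 1 and a number 9 percentage points lower (within the scatter) from compound 3 to compound 4, 0.4 percentage points apart, within the scatter of two such steps

Going by these compounds alone, on both cores, then, this read-out at a single concentration does not separate the two groups, although that rests on only two pairs of compounds, and steps within the scatter do not establish that the groups are equivalent. Compounds 1 and 2 are ureas and compounds 3 and 4 are thioureas on a different core, so these pairs do not show which structural difference goes with the separate levels of the two pairs, or whether the agreement would hold on a third core.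

From the compounds shown here alone, it remains open how an amine, a carboxylic acid or a nitrile on the same aromatic carbon would compare with trifluoromethyl and nitro. A urea on the core of compound 3 and a thiourea on the core of compound 1 would also be needed to separate the linker from the core.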